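Aryl swap on the isoxazoline-bearing compound 2

The source may hold more compounds than are shown below. What is called first, only, known or untested is meant among the compounds shown, and "the series" means these compounds.

In a functional assay on A549 cells (Homo sapiens) for cytotoxicity, read by MTT assay, with a stated time of 48 h (on this read-out higher numbers stand for weaker inhibition and lower numbers for stronger inhibition), compound 2 `COc1ccc(C2=NOC(COc3ccc(-c4nnnn4-c4cc(OC)c(OC)c(OC)c4)cc3N)C2)cc1N` gives 2080 nM. Compound 1 `COc1cc(C2=NOC(c3cc(OC)c(OC)c(OC)c3)C2)ccc1O` gives 2600 nM, and compound 3 `COc1ccc(-c2nnnn2-c2cc(OC)c(OC)c(OC)c2)cc1N` gives 2630 nM. Compound 2 stands within the scatter of both, so the three values cannot be told apart.

Compound 4 `COc1cc(C2=NOC(COc3ccc(-c4nnnn4-c4cc(OC)c(OC)c(OC)c4)cc3N)C2)ccc1O` has not yet been measured. It differs from compound 2 by one change: 4-hydroxy-3-methoxyphenyl in place of 3-amino-4-methoxyphenyl on a carbon with a double bond to nitrogen. Compound 1 carries the same 4-hydroxy-3-methoxyphenyl on such a carbon and gives 2600 nM. Among the measured compounds shown here, no measured pair isolates this change, so its effect is not known directly. Since the three measured structures all fall within the scatter of one another, no step beyond the scatter is expected in this assay, and no direction is favoured. The estimated change is a 1.2-fold higher number from compound 2 to compound 4 (0.06 log units; within the scatter), which is expected to remain within the scatter. For compound 4 the estimated value is 2400 nM, with an expected range of 900 nM to 6500 nM.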

Compound 4, half-maximal inhibitory concentration: 2010 nM
Compound 4: middle estimate off by 1.2-fold (0.08 log units), on the high side; low and high end bracket the measured number.
By their numbers in this assay, from the lowest: compounds 4, 2, 1 and 3 (each within the scatter of the next).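

In this assay, among the compounds shown here, 4-hydroxy-3-methoxyphenyl in place of 3-amino-4-methoxyphenyl on the carbon with a double bond to nitrogen gives a 1.0-fold lower number from compound 2 to compound 4 (0.01 log units; within the scatter), the first direct reading of this change. The two groups match in heavy-atom, hydrogen-bond donor and hydrogen-bond acceptor counts, and with the rest of compound 2 held constant, the read-out does not separate them at this position. No measured information bears on the reason for this result.

From the compounds shown here alone, whether any group in this place can move the number beyond the scatter remains open, since both groups tested are substituted phenyl rings of the same size; an unsubstituted phenyl, a carboxylic acid on the ring or a longer alkoxy chain would test this. Going by these compounds, whether the same swap reads alike on another core also remains open.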